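The source may report more compounds than this note shows. Statements on the series, on what has been measured and on what is new or still open speak of the compounds shown alone.

Compound 1 `CSc1cc(C)c(C(=O)N=C(N)N)cc1S(C)(=O)=O`: 6 nM
Compound 2 `Cc1cc(OC2CCCC2)c(S(C)(=O)=O)cc1C(=O)N=C(N)N`: 27 nM

In a functional assay for inhibition of sodium/hydrogen exchanger (Oryctolagus cuniculus) (on this read-out higher numbers stand for weaker inhibition and lower numbers for stronger inhibition), compound 1 gives 6 nM, and compound 2 gives 27 nM, the higher of the two numbers. Among the compounds with values here, the only measured step, a 4.5-fold higher number from compound 1 to compound 2 (0.65 log units; beyond the scatter), belongs to the exchange of methylsulfanyl for cyclopentyloxy. Compound 3 `Cc1cc(C#N)c(S(C)(=O)=O)cc1C(=O)N=C(N)N` differs from compound 2 by cyano in place of cyclopentyloxy on an aromatic carbon. Within the data shown here, no measured step involves cyano, so the expectation rests on compound 1 alone. Because compound 1 with methylsulfanyl at this position gives 6 nM, removing cyclopentyloxy is expected to move the number back toward it: a 2.7-fold lower number from compound 2 to compound 3 (0.43 log units; beyond the scatter). The estimate for compound 3 is 10 nM, range 3 nM to 40 nM.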

Compound 3, half-maximal inhibitory concentration: 70 nM
Beside the measured number, compound 3's estimate is 7.0-fold (0.85 log units) below it; the measured number lies above the stated range.
By their numbers in this assay, from the lowest: compound 1; then compound 2; then compound 3.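

Exchanging cyclopentyloxy for cyano gives a 2.6-fold higher number from compound 2 to compound 3 (0.41 log units; beyond the scatter) and exchanging methylsulfanyl for cyano gives a 12-fold higher number from compound 1 to compound 3 (1.07 log units; beyond the scatter) in this assay. The count of heavy atoms alone therefore does not set the order at this position: cyano, with 2 heavy atoms, gives a higher number than cyclopentyloxy, with 6. Nothing available explains this order.

Going by these compounds, whether an amine, a methoxy group or a longer chain here would come closer to methylsulfanyl remains open. So does whether this order of the three groups would hold if the neighbouring methyl or methylsulfonyl group were changed.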